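The source may report more compounds than this note shows. Statements on the series, on what has been measured and on what is new or still open speak of the compounds shown alone.

Measured so far in an assay for inhibition of serine/threonine-protein kinase Sgk1 (Homo sapiens), with stated times of 30 min and 60 min, in the presence of a further agent that is not named here; on this read-out lower numbers stand for stronger inhibition and higher numbers for weaker inhibition:
compound 1 `CN1CCC(CNC(=O)c2cc(-c3ccc(NS(=O)(=O)c4cccc(Cl)c4Cl)cc3)nc3[nH]ncc23)C1` gives 45 nM;
compound 2 `CCN1CCC(CNC(=O)c2cc(-c3ccc(NS(=O)(=O)c4cccc(Cl)c4Cl)cc3)nc3[nH]ncc23)C1` gives 109 nM;
compound 3 `CCOc1nc(-c2ccc(NS(=O)(=O)c3cc(Cl)ccc3F)cc2)nc2[nH]nc(C)c12` gives 183 nM.

Among these three, compound 3 carries the highest number, that is the weakest inhibition. Its nearest neighbour is compound 2, whose value lies within the usual scatter of compound 3, so no order between those two can be claimed; compound 1 lies further off, beyond the scatter.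

Compound 4 `Cc1n[nH]c2nc(-c3ccc(NS(=O)(=O)c4cc(Cl)ccc4F)cc3)nc(OCC3CN(C(C)C)C3)c12` is not yet measured. It differs from compound 3 in one place: 1-isopropylazetidin-3-yl in place of methyl on a saturated chain carbon bound to an oxygen on an aromatic ring. Among the compounds with values here, the only measured single step, a 2.4-fold higher number from compound 1 to compound 2 (0.38 log units; beyond the scatter), concerns a small addition on a saturated chain carbon bound to an amine nitrogen in a ring, a different place and a much smaller change than the one from compound 3 to compound 4, so it bears on it only loosely. Within the data shown here, compounds 1 and 2, which both hold a saturated amine-containing ring, show lower numbers than compound 3, but they belong to a different core and no step is known to connect them. For compound 4 the expected step is a 1.8-fold lower number from compound 3 to compound 4 (0.26 log units; within the scatter), and its estimated value in this assay is 100 nM, with a range from 30 nM to 400 nM.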

Compound 4, half-maximal inhibitory concentration: 1 nM
The estimate for compound 4 lay 100-fold (2.00 log units) above the measured number; the measured number lies below the stated range.
By their numbers in this assay, from the lowest: compound 4; then compound 1; then compounds 2 and 3 (each within the scatter of the next).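

In this assay, the place on a saturated chain carbon bound to an oxygen on an aromatic ring accepts a far larger group than methyl, and 1-isopropylazetidin-3-yl there gives a 180-fold lower number from compound 3 to compound 4 (2.26 log units; beyond the scatter) in a single change. This is much larger than the only other step shown, a 2.4-fold higher number from compound 1 to compound 2 (0.38 log units; beyond the scatter), which lies in a different place on a different core. Nothing measured here explains why the step from ethoxy to (1-isopropylazetidin-3-yl)methoxy is so large.

The compounds shown leave open whether the ring nitrogen is needed, which cyclobutyl in place of 1-isopropylazetidin-3-yl would test. They also leave open how much depends on the isopropyl group, which a methyl or a plain hydrogen on that ring nitrogen would show.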